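The source may hold more compounds than are shown below. What is called first, only, known or untested is meant among the compounds shown, and "the series" means these compounds.

Measured so far in an assay on CHO-K1 cells for displacement of a labelled ligand from adenosine receptor A1 (Homo sapiens), read by scintillation counting, with a stated time of 60 min; on this read-out higher numbers stand for weaker inhibition and lower numbers for stronger inhibition:
Compound 1 `Nc1nc(N/N=C/c2cncs2)nc2c1ncn2[C@@H]1O[C@H](CO)[C@@H](O)[C@H]1O` gives 22 nM.
Compound 2 `Nc1nc(N/N=C/c2ccc(C(F)(F)F)cc2C(F)(F)F)nc2c1ncn2[C@@H]1O[C@H](CO)[C@@H](O)[C@H]1O` reaches only a limit of the assay, > 10000 nM.
Compound 3 `Nc1nc(N/N=C/c2ccc(-n3ccnc3)cc2)nc2c1ncn2[C@@H]1O[C@H](CO)[C@@H](O)[C@H]1O` likewise reaches only a limit of the assay, > 10000 nM.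

Compound 3 thus stands at the limit of > 10000 nM in this assay, at which 2 of the 3 values shown sit, so only a bound is known for it, and the step of an at least 450-fold higher number from compound 1 to compound 3 (2.65 log units; beyond the scatter) shows how far it has fallen away from compound 1. Compound 4 `Nc1nc(N/N=C/c2ccc(C(F)(F)F)cc2)nc2c1ncn2[C@@H]1O[C@H](CO)[C@@H](O)[C@H]1O` differs from compound 3 by trifluoromethyl in place of 1H-imidazol-1-yl on an aromatic carbon. Going by the values given here, no measured step covers this exact change. Compound 2, which carries two trifluoromethyl groups, also sits at the limit. Among the compounds with values here, nothing among the measured values therefore points toward a gain for compound 4. The step that the limit leaves unreadable from compound 3 to compound 4 is expected to stay within the scatter. Compound 4 is estimated at 15000 nM, between 3000 nM and 60000 nM, and will most likely again be reported only as a limit.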

Compound 4, inhibition constant: 37 nM
Compound 4: the middle estimate sits 410-fold (2.61 log units) above what was measured; the measured number lies below the stated range.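

In this assay, a substituted phenyl group on the hydrazone carbon need not lose binding, since trifluoromethyl in place of 1H-imidazol-1-yl gives an at least 270-fold lower number from compound 3 to compound 4 (2.43 log units; beyond the scatter). Taking away the second trifluoromethyl has a similarly large outcome, with an at least 270-fold lower number from compound 2 to compound 4 (2.43 log units; beyond the scatter). The 4-(trifluoromethyl)phenyl group also holds the level of 1,3-thiazol-5-yl, with a 1.7-fold higher number from compound 1 to compound 4 (0.23 log units; within the scatter).

From the compounds shown here alone, because compound 2 and compound 3 stay at a limit, how far each lies from compound 4 remains open: the limit of > 10000 nM in this assay, at which 2 of the 4 values shown sit. Whether an amine, a methoxy group or a carboxylic acid on the same aromatic carbon would keep this binding also remains open.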